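The source may hold more compounds than are shown below. What is called first, only, known or untested is meant among the compounds shown, and "the series" means these compounds.

Measured compounds, with their readings in a physicochemical assay for acid dissociation:

compound 1, `COc1cccc(CNCCCNc2ccnc3cc(CC(C)C)ccc23)c1O`: compound 1 gives 9.47
compound 2, `COc1cccc(CNCCCNc2ccnc3cc(Oc4ccc(C(C)(C)C)cc4)ccc23)c1O`: compound 2 gives 9.28
compound 3, `COc1cccc(CNCCCNc2ccnc3cc(Cc4ccc(F)cc4Cl)ccc23)c1O`: compound 3 gives 9.47

Compound 3 sits level with compound 1 at the digits shown, and the two together hold the highest readings of the three; its nearest neighbour is compound 1, with no change at the digits printed from compound 1 to compound 3 (within the scatter), and its furthest is compound 2, with a number 0.19 log units higher from compound 2 to compound 3 (within the scatter). All three readings lie within the scatter of one another.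

Compound 4, `COc1cccc(CNCCCNc2ccnc3cc(-c4cccc5ccccc45)ccc23)c1O`, differs from compound 3 by naphthalen-1-yl in place of 2-chloro-4-fluorobenzyl on an aromatic carbon.

Going by the values given here, the steps that bear on this change are those that alter the same position of the shared core while the rest of the molecule stays fixed: a number 0.19 log units lower from compound 1 to compound 2 (within the scatter) and no change at the digits printed from compound 1 to compound 3 (within the scatter), and between the two aromatic replacements a number 0.19 log units higher from compound 2 to compound 3 (within the scatter). None of these reached beyond the scatter, whether the group was a branched chain, an aryl ether or a substituted benzyl. A further aromatic group at this position is therefore expected to leave this assay unchanged beyond the scatter, with a number 0.07 log units lower from compound 3 to compound 4 (within the scatter) as the expected step.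

Compound 4 is estimated at 9.4, in the range 9.1 to 9.7.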

Compound 4, acid dissociation constant: 9.47
Beside the measured number, compound 4's estimate is 0.07 log units below it; the measured number falls inside the stated range.
By their numbers in this assay, from the lowest: compounds 2, 1, 3 and 4 (each within the scatter of the next).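

In this assay the step of no change at the digits printed from compound 3 to compound 4 (within the scatter) brings in naphthalen-1-yl on the aromatic carbon, a group of 2 six-membered aromatic rings of carbon only that lacks the chlorine and fluorine of 2-chloro-4-fluorobenzyl. The same group gives a number 0.19 log units higher from compound 2 to compound 4 (within the scatter) against 4-(tert-butyl)phenoxy and no change at the digits printed from compound 1 to compound 4 (within the scatter) against isobutyl, so this fourth kind of group also stays within the scatter of every other compound. A branched chain, an aryl ether, a substituted benzyl and a fused aromatic group therefore read alike at this position, and none of the four compounds goes against that pattern.

Going by these compounds, whether an amine or a carboxylic acid at this position would also stay within the scatter remains open, as does the outcome of a longer chain elsewhere on the shared core. No supporting measurement is available to explain why the readings stay level across these groups.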